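Cytotoxicity of the diol cyclopentane acrylamide series

The source may hold more compounds than are shown below. What is called first, only, known or untested is meant among the compounds shown, and "the series" means these compounds.

Compound 2 `CCNC(=O)/C=C/[C@H]1C[C@@H](O)[C@@H](O)C1` is the amide of the shared core; in an ADME assay on S2 cells (Drosophila melanogaster) for cytotoxicity, read by MTT assay (on this read-out lower numbers stand for an effect already at smaller amounts and higher numbers for an effect only at larger amounts of compound), compound 2 gives > 250000 nM, a limit of the assay and not a number. Compound 1 `COC(=O)/C=C/[C@H]1C[C@@H](O)[C@@H](O)C1` is the methyl ester; in this assay compound 1 gives > 350000 nM, also only a limit. Compound 3 `O=C(O)/C=C/[C@H]1C[C@@H](O)[C@@H](O)C1` is the free acid; in this assay compound 3 gives > 350000 nM, again a limit. So compound 2 stands at the limit of > 250000 nM in this assay, at which 1 of the 3 values shown sits, while the other two sit at the limit of > 350000 nM in this assay, at which 2 of the 3 values shown sit. Among the measured compounds shown here, the steps a step that the two limits leave unreadable from compound 1 to compound 2, a step that the two limits leave unreadable from compound 1 to compound 3 and a step that the two limits leave unreadable from compound 2 to compound 3 are therefore all unreadable, and no measured step gives a readable size.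

Compound 4 `O=C(/C=C/[C@H]1C[C@@H](O)[C@@H](O)C1)Nc1ccncc1` differs from compound 2 by pyridin-4-yl in place of ethyl on an amide-type nitrogen. None of the three measured steps reads out, so no direction beyond the scatter can be taken from them; the ester, acid and ethyl amide all remain at their limits. Compound 4 is expected to stay near these limits, with a step of an at least 1.2-fold lower number from compound 2 to compound 4 (0.09 log units; that floor lies within the scatter) estimated from compound 2. The estimate for compound 4 in this assay is 200000 nM, within 50000 nM to 400000 nM.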

Compound 4, half-maximal effective concentration: > 200000 nM
Compound 4 was reported as a limit; the forecaster's own chance of this, stated with the estimate: 60%; the middle value sits exactly at the limit.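

In this assay compound 4 gives > 200000 nM, a limit of the assay and not a number; compound 2 also stands only at a limit, so the step between them cannot be read. The concentration at which any compound shown takes effect remains open.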